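Swapping the ring substituent: from cyclopentenyl to methoxycarbonyl

The source may report more compounds than this note shows. Statements on the series, on what has been measured and on what is new or still open speak of the compounds shown alone.

Measured compounds in an assay on isolated protein for inhibition of tyrosine-protein kinase receptor UFO (Homo sapiens), read by FRET and Z'-LYTE, with a stated time of 1.5 h; a lower number here means a stronger inhibitor, a higher number a weaker inhibitor:
- compound 1, `Cc1c(C(=O)Nc2ccc(Oc3ncnc4[nH]cc(-c5ccccc5)c34)c(F)c2)c(=O)c2cc(Cl)ccc2n1C`, gives 1890 nM
- compound 2, `Cc1ccc2c(c1)c(=O)c(C(=O)Nc1ccc(Oc3ncnc4[nH]cc(-c5ccccc5)c34)c(F)c1)c(C)n2C`, gives 100 nM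
- compound 3, `Cc1c(C(=O)Nc2ccc(Oc3ncnc4[nH]cc(-c5ccccc5)c34)c(F)c2)c(=O)c2cc(C3=CCCC3)ccc2n1C`, gives 3320 nM

Compound 3 has the highest number of the three in this assay; it sits close to compound 1, since a 1.8-fold higher number from compound 1 to compound 3 (0.24 log units; within the scatter), but far from compound 2, since a 33-fold higher number from compound 2 to compound 3 (1.52 log units; beyond the scatter). Compound 4, `COC(=O)c1ccc2c(c1)c(=O)c(C(=O)Nc1ccc(Oc3ncnc4[nH]cc(-c5ccccc5)c34)c(F)c1)c(C)n2C`, is compound 3 with methoxycarbonyl in place of cyclopent-1-en-1-yl on an aromatic carbon. Within the data shown here, no measured step involves methoxycarbonyl. The steps at this position show that methyl gives a strong inhibitor (a 19-fold lower number from compound 1 to compound 2 (1.28 log units; beyond the scatter)), while chloro and cyclopent-1-en-1-yl both give weak ones. Among the measured compounds shown here, with no direct precedent, compound 4 is expected to stay near compound 3: a 1.7-fold lower number from compound 3 to compound 4 (0.22 log units; within the scatter), not beyond the scatter, with wide uncertainty. The estimate for compound 4 in this assay is therefore 2000 nM, within 400 nM to 10000 nM.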

Compound 4, half-maximal inhibitory concentration: > 10000 nM
Compound 4: a limit, no number; the forecaster's own chance of this, stated with the estimate: 10%; at least 5.0-fold (0.69 log units) between middle value and limit.
By their numbers in this assay, from the lowest: compound 2; then compounds 1 and 3 (each within the scatter of the next). At a limit, above all of these: compound 4.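

In this assay compound 4 gives only a limit, > 10000 nM, not a number. Methoxycarbonyl is thus the weakest of the four groups at this aromatic carbon: an at least 3.0-fold higher number from compound 3 to compound 4 (0.47 log units; beyond the scatter), an at least 5.2-fold higher number from compound 1 to compound 4 (0.72 log units; beyond the scatter) and an at least 100-fold higher number from compound 2 to compound 4 (2.00 log units; beyond the scatter). Replacing the all-carbon ring with a group carrying hydrogen-bond acceptors brings no recovery towards compound 2.

As far as these compounds go, how far compound 4 lies past its limit stays open. So does whether the strength seen with methyl extends to ethyl, or whether an amine at this carbon would keep it.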